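This account rests on a few compounds, and the source may have more. Where it says the series, first, only, none or still open, it means among the compounds named here.

Compound 1 `Cc1ccc2oc(CSc3nnc(N)s3)cc(=O)c2c1`: in a functional assay on HEp-2 cells (Homo sapiens) for cytotoxicity, read by MTT assay, with a stated time of 72 h (a higher number here means a weaker inhibitor, a lower number a stronger inhibitor), compound 1 gives only a limit, > 25000 nM.
Compound 2 `Cc1cc(C)n2nc(SCc3cc(=O)c4cc(Cl)ccc4o3)nc2n1`: in this assay compound 2 gives only a limit, > 25000 nM.
Compound 3 `Cc1nnc(SCc2cc(=O)c3cc(Cl)ccc3o2)o1`: in this assay compound 3 gives only a limit, > 25000 nM.

Compound 2 therefore stands at the limit of this assay rather than at a number, and the same is true of every other value shown, as the limit of > 25000 nM in this assay, at which 3 of the 3 values shown sit, records. Going by the values given here, no step between measured compounds is available here. Compound 4 `Cc1cc(C)n2nc(SCc3cc(=O)c4ccccc4o3)nc2n1` differs from compound 2 by hydrogen in place of chloro on an aromatic carbon. With every measured compound sitting at the limit, no change beyond the usual scatter is expected from compound 2 to compound 4 in this assay, and the step that the limit leaves unreadable from compound 2 to compound 4 is the estimate meant. Compound 4 is expected to give about 30000 nM, within a range from 15000 nM to 80000 nM, most likely again reported only as a limit.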

Compound 4, half-maximal inhibitory concentration: > 25000 nM
Compound 4 ended at the assay's limit; the forecaster's own chance of this, stated with the estimate: 85%; the middle value lies beyond the limit too.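

Going by these compounds alone, compound 2 and compound 4 both give only a limit in this assay, and no step between them can be read. The compounds shown leave open whether chloro or hydrogen on that aromatic carbon makes any difference to cytotoxicity.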